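This account rests on a few compounds, and the source may have more. Where it says the series, first, only, none or still open, it means among the compounds named here.

Measured so far in an in vitro ADME assay on microsomes from liver (Mus musculus) for metabolic stability, tested at 0.2 uM; a higher number here means faster removal of the compound, a lower number slower removal:
- compound 1 `Cc1c(COc2ccnc(OCC3CCOCC3)c2)[nH]c2ccccc2c1=O` gives 203 mL/min/kg
- compound 2 `CC(C)c1c(COc2cccc(OCC3CCOCC3)c2)[nH]c2ccccc2c1=O` gives "not determined" (no result reported)

Compound 2 has no place on this scale. No result was reported for it, so there is no number to compare with anything else. The only figure in this small set belongs to compound 1, whose structure differs from that of compound 2 in more than one place.

Compound 3 `O=c1cc(COc2cccc(OCC3CCOCC3)c2)[nH]c2ccccc12` has not yet been measured. The structural change is hydrogen in place of isopropyl on an aromatic carbon, which means hydrogen in place of isopropyl on an aromatic carbon. Among the measured compounds shown here, with no number for compound 2 and no measured step of this kind, the data give neither a size nor a direction for this change. The working expectation in this assay is therefore no step beyond the usual scatter. For the measured compounds named here, the only available anchor is compound 1 at 203 mL/min/kg, so fast removal is also expected for compound 3, though with wide uncertainty.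

The estimated clearance of compound 3 is 150 mL/min/kg, with an expected range from 70 mL/min/kg to 320 mL/min/kg.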

Compound 3, clearance: 197 mL/min/kg
For compound 3 the middle estimate is 1.3-fold (0.12 log units) below the measured one; measured number inside the range.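

Compound 3 gives 197 mL/min/kg in this assay, but no step can be read from this result: compound 2 has no number to compare, and compound 1 differs from compound 3 in more than one place. As far as these compounds go, the effect on clearance of exchanging isopropyl for hydrogen therefore stays open, in both size and direction. Nothing available bears on this result.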